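The source may hold more compounds than are shown below. What is called first, only, known or untested is meant among the compounds shown, and "the series" means these compounds.

Among the compounds with values here, in a functional assay on KB cells (Homo sapiens) for cytotoxicity, read by MTT assay, with a stated time of 72 h (on this read-out higher numbers stand for an effect only at larger amounts of compound and lower numbers for an effect already at smaller amounts), two compounds have numbers so far. Compound 1 `CCOC(=O)c1c(C)coc1-c1ccc2c(CC)cccc2c1OC` gives 2.2 ug/mL, and compound 2 `CCOc1c(-c2occ(C)c2C(=O)OC)ccc2c(CC)cccc12` gives 1.8 ug/mL. Within the data shown here, these two values lie within the usual scatter of each other, so compound 1 stands level with the only other measured compound and neither can be ranked. Among the measured compounds shown here, the two compounds differ in more than one place, and no single-place step between measured compounds is available to guide a forecast. Compound 3 `CCc1cccc2c(OC)c(-c3occ(C)c3CBr)ccc12` has not yet been measured in this assay. It departs from compound 1 in one place: bromomethyl in place of ethoxycarbonyl on an aromatic carbon. For the measured compounds named here, in words, this puts bromomethyl in place of ethoxycarbonyl on an aromatic carbon, a change for which the measured compounds offer no precedent. Only a modest step is therefore expected, leaning towards a somewhat lower number and possibly no larger than the scatter, although the uncertainty is wide in both directions. The expected move is a 1.5-fold lower number from compound 1 to compound 3 (0.17 log units; within the scatter). For compound 3 the estimated value is 1.5 ug/mL, with an expected range from 0.4 ug/mL to 5 ug/mL.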

Compound 3, concentration for half-maximal effect: > 10 ug/mL
Compound 3: a limit, no number; the forecaster's own chance of this, stated with the estimate: 8%; at least 6.6-fold (0.82 log units) between middle value and limit.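

In this assay compound 3 gives > 10 ug/mL, which is a limit of the assay and not a number: the limit of > 10 ug/mL in this assay, at which 1 of the 3 values shown sits. Even so, the exchange of ethoxycarbonyl for bromomethyl can be read as an at least 4.5-fold higher number from compound 1 to compound 3 (0.65 log units; beyond the scatter), and this step lies beyond the usual scatter. Within the data shown here, the earlier compounds gave no single-place step at all, so this is the first sign that the read-out depends on the group carried on this aromatic carbon of the five-membered aromatic ring with 1 oxygen, and that a change at this one place is enough to move it clearly towards larger amounts of compound.

A single step cannot separate the loss of ethoxycarbonyl from the arrival of bromomethyl, and it gives no true size for the shift, nor any cause for it. Going by these compounds, it remains open how this position would respond to a carboxylic acid, an amide, a hydroxymethyl group or a longer ester chain, and so whether the carbonyl of the ester is what matters here.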